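A few compounds are considered here, and "the series" means these few. Any claim that something is new, unique, unknown or untested is made for them only; others in the source may bear on it.

Working notes on the series. Cytotoxicity here is read in a functional assay on THP-1 cells (Homo sapiens) for cytotoxicity, read by sulforhodamine B assay, with a stated time of 48 h; a higher number here means a weaker inhibitor, a lower number a stronger inhibitor. Among the compounds with values here, compound 1 `COc1ccc(/C=C/C(=O)/C=C/c2ccc(OCc3cn(CCOc4cc(=O)oc5ccccc45)nn3)c(OC)c2)cc1OC` gives 2340 nM in this assay, the lowest of the three numbers so far. Compound 2 `COc1cc(/C=C/C(=O)/C=C/c2cccc3ccccc23)ccc1OCc1cn(CCCOc2cc(=O)oc3ccccc23)nn1` gives 8410 nM, and compound 3 `COc1ccc(/C=C/C(=O)/C=C/c2ccc(OCc3cn(CCCOc4cc(=O)oc5ccccc45)nn3)c(OC)c2)cc1OC` gives 8510 nM; each of these stands above compound 1 by more than the scatter, and compound 3 differs from compound 1 only in the linking chain. Within the data shown here, the one step measured at the aryl end of the chain is a 1.0-fold higher number from compound 2 to compound 3 (0.01 log units; within the scatter), so that swap of aryl group left the number unchanged.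

Compound 4 `COc1cc(/C=C/C(=O)/C=C/c2cccs2)ccc1OCc1cn(CCOc2cc(=O)oc3ccccc23)nn1` differs from compound 1 by thiophen-2-yl in place of 3,4-dimethoxyphenyl on a double-bonded chain carbon bound to a double-bonded chain carbon. This is a change at the same place as the measured step from compound 2 to compound 3, and that step lay within the scatter. Among the measured compounds shown here, no measured pair shows thiophen-2-yl at this place, so the only bearing evidence is that one aryl swap at this place did nothing. The expectation for compound 4 in this assay is therefore no step beyond the scatter, with the range widened to allow for the untested group.

Compound 4 is expected to give 3000 nM in this assay, within 1200 nM to 8000 nM. This estimate means a 1.3-fold higher number from compound 1 to compound 4 (0.11 log units; within the scatter) is expected.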

Compound 4, half-maximal inhibitory concentration: 7140 nM
For compound 4 the middle estimate is 2.4-fold (0.38 log units) below the measured one; the measured number falls inside the stated range.
By their numbers in this assay, from the lowest: compound 1; then compounds 4, 2 and 3 (each within the scatter of the next).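

In this assay this position is not indifferent to the aryl group: thiophen-2-yl in place of 3,4-dimethoxyphenyl gives a 3.1-fold higher number from compound 1 to compound 4 (0.48 log units; beyond the scatter) and so lies beyond the scatter, whereas the earlier swap at the same place, a 1.0-fold higher number from compound 2 to compound 3 (0.01 log units; within the scatter) on the other linking chain, lay within it. The silence of that first swap therefore does not extend to every aryl group here, and on the linking chain of compound 1 the 3,4-dimethoxyphenyl group is the better of the two groups shown, though only by a modest step. No measurement shown accounts for this step, which replaces a six-membered aromatic ring of carbon only with a five-membered aromatic ring with 1 hetero atom and also removes the methoxy groups.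

The compounds shown leave open whether the ring or its methoxy groups carry the step, which an unsubstituted phenyl or a 4-methoxyphenyl group on the linking chain of compound 1 would help to separate. They also leave open whether thiophen-2-yl or naphthalen-1-yl would behave the same way on each linking chain, and whether a furan-2-yl group would follow thiophen-2-yl at this place.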